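Carbonyl side chains: compound 3 to compound 4

The compounds below may be only part of what the source reports. "The series", "measured", "known", "first", "only" and "open" are said of these compounds alone.

Values measured in a functional assay on PC-3 cells (Homo sapiens), read by MTT assay, with a stated time of 48 h (on this read-out higher numbers stand for weaker inhibition and lower numbers for stronger inhibition), are as follows.
- compound 1 `CCOC(=O)CN(C)C(=O)c1ccc(C(CC)(CC)c2ccc(OCC(O)C(C)(C)C)c(C)c2)n1CC` gives 25500 nM
- compound 2 `C#CCNC(=O)c1ccc(C(CC)(CC)c2ccc(OCC(O)C(C)(C)C)c(C)c2)n1CC` gives 16200 nM
- compound 3 `CCn1c(C(=O)NCCN)ccc1C(CC)(CC)c1ccc(OCC(O)C(C)(C)C)c(C)c1` gives 940 nM

Compound 3 has the lowest number of the three, and its gaps to both others lie beyond the scatter. The next compound is compound 4 `CCn1c(C(=O)N(C)CCC#N)ccc1C(CC)(CC)c1ccc(OCC(O)C(C)(C)C)c(C)c1` and it has not been measured. The change is (2-cyanoethyl)(methyl)amino in place of (2-aminoethyl)amino on a carbonyl carbon and it places (2-cyanoethyl)(methyl)amino in place of (2-aminoethyl)amino on a carbonyl carbon.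

Two large measured steps bear on it, namely a 27-fold lower number from compound 1 to compound 3 (1.43 log units; beyond the scatter) and a 17-fold lower number from compound 2 to compound 3 (1.24 log units; beyond the scatter) with each one bringing in (2-aminoethyl)amino. Compound 4 loses that group. The two measured compounds without it stay close, with a 1.6-fold lower number from compound 1 to compound 2 (0.20 log units; within the scatter) inside the scatter. A large step to a higher number is therefore expected in this assay of about the size of those two steps. The estimate amounts to an expected 19-fold higher number from compound 3 to compound 4 (1.28 log units; beyond the scatter) on this basis. For compound 4 the estimated value is 18000 nM with an expected range from 7000 nM to 40000 nM on the evidence of three compounds only.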

Compound 4, half-maximal inhibitory concentration: 1700 nM
Estimate against measurement, compound 4: 11-fold (1.02 log units) above; measured number below the stated range.
By their numbers in this assay, from the lowest: compounds 3 and 4 (each within the scatter of the next); then compounds 2 and 1 (each within the scatter of the next).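

In this assay, (2-cyanoethyl)(methyl)amino can take the place of (2-aminoethyl)amino on the carbonyl carbon with a 1.8-fold higher number from compound 3 to compound 4 (0.26 log units; within the scatter) and no change beyond the scatter. Low numbers in this pair therefore do not require the amine or any hydrogen-bond donors in the entering group. Loss of the amine alone does not lead to the high numbers either: compound 4 keeps its distance from the other two side chains, with a 9.5-fold lower number from compound 2 to compound 4 (0.98 log units; beyond the scatter) and a 15-fold lower number from compound 1 to compound 4 (1.18 log units; beyond the scatter) as the modest and large steps, so compounds 1 and 2 go against any rule that ties low numbers to the amine.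

The nitrile and the methyl on the amide nitrogen remain unseparated, and a (2-cyanoethyl)amino chain, a dimethylamino chain end or a carboxylic acid would test each separately. No measurement at hand explains why these side chains differ.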